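This account rests on a few compounds, and the source may have more. Where it says the series, first, only, none or still open, it means among the compounds named here.

Measured compounds:
Compound 1, `COc1cc(C(=O)/C=C/c2cn(-c3ccccc3)nc2-c2ccsc2)cc(OC)c1OC`: 4900 nM
Compound 2, `COc1cc(C(=O)/C=C/c2cn(-c3ccccc3)nc2-c2cccnc2)cc(OC)c1OC`: 14500 nM
Compound 3, `COc1ccc(C(=O)/C=C/c2cn(-c3ccccc3)nc2-c2cccnc2)cc1OC`: 1700 nM

All three numbers come from a functional assay on MCF7 cells (Homo sapiens) for inhibition, read by sulforhodamine B assay, with a stated time of 72 h; a lower number here means a stronger inhibitor, a higher number a weaker inhibitor. Compound 2 gives the highest number of the three, so it is the weakest inhibitor among them: a 3.0-fold higher number from compound 1 to compound 2 (0.47 log units; beyond the scatter), and an 8.5-fold lower number from compound 2 to compound 3 (0.93 log units; beyond the scatter). Compound 4, `COc1cc(C(=O)/C=C/c2cn(-c3ccccc3)nc2-c2ccncc2)cc(OC)c1OC`, has not yet been measured. It differs from compound 2 in one place: pyridin-4-yl in place of pyridin-3-yl on an aromatic carbon. Among the measured compounds shown here, no measured step swaps one pyridyl ring for another at this place on the shared core. The nearest comparison is the step from compound 1 to compound 2, which exchanged thiophen-3-yl for pyridin-3-yl at the same place and moved the number only modestly. The removal of a methoxy group, seen in the step from compound 2 to compound 3, concerns a different part of the molecule and gives no guidance on this change. A shift within the scatter, or at most a small one in either direction, is therefore expected for compound 4, and its step from compound 2 is estimated as a 1.3-fold lower number from compound 2 to compound 4 (0.12 log units; within the scatter). Compound 4 is thus expected to give about 11000 nM, within an estimated range of 3500 nM to 35000 nM.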

Compound 4, half-maximal inhibitory concentration: 3500 nM
Beside the measured number, compound 4's estimate is 3.1-fold (0.50 log units) above it; low and high end bracket the measured number.
By their numbers in this assay, from the lowest: compound 3; then compounds 4 and 1 (each within the scatter of the next); then compound 2.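

Shifting only the place of the ring nitrogen matters at this position: in this assay there is a 4.1-fold lower number from compound 2 to compound 4 (0.62 log units; beyond the scatter) even though pyridin-3-yl and pyridin-4-yl have the same atoms and the same counts of hydrogen-bond donors and acceptors. The earlier step from thiophen-3-yl to pyridin-3-yl therefore does not speak for pyridine rings in general, as the other pyridine ring shows a 1.4-fold lower number from compound 1 to compound 4 (0.15 log units; within the scatter) and so stands within the scatter of thiophen-3-yl. Nothing shown here explains why the two pyridine rings differ.

As far as these compounds go, it remains open whether the same swap keeps its size on the core of compound 3, which has one methoxy group fewer. From the compounds shown here alone, how a pyridin-2-yl ring, or a phenyl ring carrying an amine, would read at this place is also open.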